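Acetylation of the free hydroxy in a lactone series

The compounds below may be only part of what the source reports. "The series", "measured", "known", "first", "only" and "open" are said of these compounds alone.

Measured compounds:
compound 1, `CC(=O)O[C@@H](C)[C@@H](/C=C/[C@@H]1O[C@@H]1[C@H]1CC=CC(=O)O1)OC(C)=O`, 2.9 ug/mL
compound 2, `CCCC[C@H](O)/C=C\[C@@H]1OC(=O)C=C[C@@H]1OC(C)=O`, 1.4 ug/mL
compound 3, `CC(=O)O[C@H](/C=C\[C@H]1CC=CC(=O)O1)C[C@@H](OC(C)=O)[C@H](C)OC(C)=O`, 3.6 ug/mL

In a functional assay on KB cells (Homo sapiens) for cytotoxicity, read by sulforhodamine B assay, with a stated time of 72 h (a lower number here means that less compound is needed, a higher number that more compound is needed for the effect), compound 2 gives 1.4 ug/mL, the lowest number of the three. The nearest is compound 1 with 2.9 ug/mL, a gap beyond the scatter, and compound 3 with 3.6 ug/mL lies further still, also beyond the scatter. On these numbers compound 2 is the most potent of the measured set, and the only one of the three that carries a free hydroxy group.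

Compound 4, `CCCC[C@@H](/C=C\[C@@H]1OC(=O)C=C[C@@H]1OC(C)=O)OC(C)=O`, has not yet been measured in this assay. It differs from compound 2 in one place: acetyl in place of hydrogen on an oxygen on a saturated carbon. Cut one bond further out, this reads as hydroxy to acetoxy. Within the data shown here, no pair of measured compounds differs by this change alone, so the size of the step cannot be read from the data; compound 1 and compound 3 both carry only acetoxy groups, but on different cores, and they say nothing direct about this step.

The step from compound 2 to compound 4 is expected to be small, a 1.8-fold higher number from compound 2 to compound 4 (0.25 log units; within the scatter), a modest rise in the number that may not exceed the scatter. For compound 4 the estimate in this assay is 2.5 ug/mL, with a likely range from 1 ug/mL to 6 ug/mL.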

Compound 4, concentration for half-maximal effect: 1.8 ug/mL
Estimate against measurement, compound 4: 1.4-fold (0.14 log units) above, within the range that was stated.
By their numbers in this assay, from the lowest: compounds 2, 4, 1 and 3 (each within the scatter of the next, the first and the last beyond it).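

In this assay, the step from hydroxy to acetoxy on this saturated carbon is a 1.3-fold higher number from compound 2 to compound 4 (0.11 log units; within the scatter). Among these compounds, this is the first direct reading of the change, and it shows that the free hydroxy does not separate compound 2 from its acetate in this cytotoxicity read-out. The hydrogen on this oxygen can therefore be replaced by acetyl without a shift that exceeds the scatter, although this rests on a single matched pair and cannot be extended to the cores of compound 1 or compound 3. The data offer no measured property or other evidence that bears on this result.

Still open, on these data alone, is whether this position stays as flat with a larger or different group on the oxygen, such as a benzoyl ester or a methyl ether, or with an amine in place of the hydroxy. Also open, as far as these compounds go, is whether the same holds for the other acetoxy group on the shared core, or with a longer chain in place of the saturated chain on this carbon.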